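Naphthoquinone esters: chain extension on the hexanoate

A few compounds are considered here, and "the series" means these few. Any claim that something is new, unique, unknown or untested is made for them only; others in the source may bear on it.

Measured so far:
compound 1, `CCCCCCC(C)C(=O)NCC(C)(C)CC1=C(O)C(=O)c2ccccc2C1=O`: 15500 nM
compound 2, `CCCCCC(=O)OCC(C)(C)CC1=C(O)C(=O)c2ccccc2C1=O`: 169000 nM

In an ADME assay on Vero cells (Chlorocebus sabaeus) for cytotoxicity, read by reporter gene assay, with a stated time of 4 days (on this read-out lower numbers stand for stronger inhibition and higher numbers for weaker inhibition), compound 2 gives 169000 nM, the higher of the two numbers recorded; compound 1 gives the lower, and the gap between the two lies beyond the scatter. Within the data shown here, no step between measured compounds connects a single structural change to a change in number, so the move to compound 3, `CCCCCCCCCCCCCCCCCC(=O)OCC(C)(C)CC1=C(O)C(=O)c2ccccc2C1=O`, rests on expectation alone. Compound 3 differs from compound 2 by dodecyl in place of hydrogen on a saturated chain carbon, five bonds along the chain from a carbonyl carbon. Among the measured compounds shown here, with no measured step to lean on, a small to moderate shift toward a lower number in this assay is expected, though a result within the scatter of compound 2 would not surprise. Compound 3 is estimated at 80000 nM, in the range 20000 nM to 300000 nM, which is expected to mean a step of a 2.1-fold lower number from compound 2 to compound 3 (0.32 log units; beyond the scatter).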

Compound 3, half-maximal inhibitory concentration: 15500 nM
Compound 3: middle estimate off by 5.2-fold (0.71 log units), on the high side; measured number below the stated range.
By their numbers in this assay, from the lowest: compounds 1 and 3 (each within the scatter of the next); then compound 2.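

In this assay, among these compounds, dodecyl in place of hydrogen on a saturated chain carbon, five bonds along the chain from a carbonyl carbon, gives an 11-fold lower number from compound 2 to compound 3 (1.04 log units; beyond the scatter) as the first single-change step. This chain position is therefore not silent: an added group with no ring, no hydrogen-bond donors or acceptors and no net charge moves the number well beyond the scatter, toward stronger inhibition. No supporting measurement bears on the reason for this step.

Two chains alone cannot show whether the number falls gradually along the chain or changes abruptly at some length. Octyl at the same place, or a dodecyl chain ending in a carboxylic acid or an amine, would separate the effect of chain length from that of the chain end.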